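Trimming the Ring Substituent Down to Hydrogen

A few compounds are considered here, and "the series" means these few. Any claim that something is new, unique, unknown or untested is made for them only; others in the source may bear on it.

Of the compounds shown here, three sharing one core have been measured in an assay on isolated protein for inhibition of CCR4-NOT transcription complex subunit 7 (Homo sapiens), read by fluorescence; on this read-out higher numbers stand for weaker inhibition and lower numbers for stronger inhibition. Compound 1 `O=c1[nH]c2ncn(C3CCCCC3)c2c(=O)n1O` gives 28200 nM, compound 2 `O=c1[nH]c2ncn(Cc3ccccc3)c2c(=O)n1O` gives 10400 nM, and compound 3 `O=c1[nH]c2ncn(Cc3ccccn3)c2c(=O)n1O` gives 10600 nM. Compound 3 thus holds the second highest of the three numbers: its value lies within the scatter of compound 2, while compound 1 gives a higher number than compound 3. Among the compounds with values here, the single one-point step known, a 1.0-fold higher number from compound 2 to compound 3 (0.01 log units; within the scatter), shows that exchanging phenyl for pyridin-2-yl changed nothing beyond the scatter. Compound 4 `Cn1cnc2[nH]c(=O)n(O)c(=O)c21` goes further: hydrogen in place of pyridin-2-yl on a saturated chain carbon bound to an aromatic nitrogen. Within the data shown here, no measured step covers removal of the whole ring, so the expectation leans on compound 1, whose saturated substituent gave the weakest value, 28200 nM. Compound 4 is therefore expected to give a higher number, estimated at 30000 nM within 12000 nM to 90000 nM, a step of a 2.8-fold higher number from compound 3 to compound 4 (0.45 log units; beyond the scatter).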

Compound 4, half-maximal inhibitory concentration: 251000 nM
The estimate for compound 4 lay 8.4-fold (0.92 log units) below the measured number; measured number outside the range, above it.
By their numbers in this assay, from the lowest: compounds 2 and 3 (each within the scatter of the next); then compound 1; then compound 4.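

In this assay the ring on the saturated chain carbon bound to an aromatic nitrogen turns out to matter: pyridin-2-yl and phenyl could stand in for each other, yet removing either gives a 24-fold higher number from compound 3 to compound 4 (1.37 log units; beyond the scatter) and a 24-fold higher number from compound 2 to compound 4 (1.38 log units; beyond the scatter) as the price. Methyl in place of cyclohexyl on an aromatic nitrogen likewise gives an 8.9-fold higher number from compound 1 to compound 4 (0.95 log units; beyond the scatter) on the same read-out, so compound 4 sits beyond the scatter of all three ringed compounds. As far as these compounds go, whether an ethyl group or a longer chain without a ring would recover part of this loss stays open. Nothing available gives a reason for these steps.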